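Two Analogues with Level Inhibition Numbers and a Rearranged Butyl Chain

A few compounds are considered here, and "the series" means these few. Any claim that something is new, unique, unknown or untested is made for them only; others in the source may bear on it.

Compound 1, `COc1cc(/C=C/C(=O)/C=C(/C=C/c2ccc(OC(C)=O)c(OC)c2)NC2CCCCC2)ccc1OC(C)=O`: 0.01%
Compound 2, `COc1cc(/C=C/C(=O)/C=C(/C=C/c2ccc(OC(C)=O)c(OC)c2)NCC(C)C)ccc1OC(C)=O`: 0%

In a functional assay for inhibition, read by spectrophotometry, with a stated time of 30 min, tested at 1 uM (a lower number here means less inhibition, a higher number more inhibition at the concentration tested (going by the name of the read-out)), compound 1 gives 0.01% while compound 2 gives 0%. Compound 2 holds the lowest of the two numbers, with compound 1 nearest to it; the step of a number 0 percentage points lower from compound 1 to compound 2 (within the scatter) lies within the scatter. Compound 3, `CCC(C)NC(=C\C(=O)/C=C/c1ccc(OC(C)=O)c(OC)c1)/C=C/c1ccc(OC(C)=O)c(OC)c1`, differs from compound 2 by sec-butyl in place of isobutyl on an amine nitrogen. Within the data shown here, only the step from compound 1 to compound 2 bears on this change, and it was flat, so no step beyond the scatter is expected, no change at the digits printed from compound 2 to compound 3 (within the scatter). Compound 3 is therefore estimated at 0%, within a range from -8% to 10%.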

Compound 3, a percentage reported as inhibition, at one concentration (the size of the read-out at that concentration, not a potency): 0%
Beside the measured number, compound 3's estimate shows no gap at the digits printed; the measured number falls inside the stated range.
By their numbers in this assay, from the lowest: compounds 2, 3 and 1 (each within the scatter of the next).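

In this assay, sec-butyl in place of isobutyl gives no change at the digits printed from compound 2 to compound 3 (within the scatter), and sec-butyl in place of cyclohexyl gives a number 0 percentage points lower from compound 1 to compound 3 (within the scatter). Rearranging the same atoms on the amine nitrogen therefore leaves the number as flat as the earlier swap of cyclohexyl for isobutyl did. With all three numbers at or near nothing, this flatness says little about the position itself. On these data alone, it remains open whether a benzyl group or a chain ending in a carboxylic acid on that nitrogen would lift the number. No other measurement bears on this result.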